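The compounds below may be only part of what the source reports. "The series", "measured", "known", "first", "only" and "open" are said of these compounds alone.

Working notes on the series.

Compound 1 `COc1cc(/C=C2\CN(S(=O)(=O)c3ccc(F)cc3)C/C(=C\c3cc(OC)c(OC)c(OC)c3)C2=O)cc(OC)c1OC` gives 4200 nM in a functional assay on HepG2 cells (Homo sapiens) for cytotoxicity, read by MTT assay, with a stated time of 24 h; on this read-out lower numbers stand for stronger inhibition and higher numbers for weaker inhibition. Compound 2 `COc1cc(/C=C2\CN(S(=O)(=O)c3ccc(NC(C)=O)cc3)C/C(=C\c3cc(OC)c(OC)c(OC)c3)C2=O)cc(OC)c1OC` gives 3890 nM in this assay; the change acetamido in place of fluoro on an aromatic carbon produced a 1.1-fold lower number from compound 1 to compound 2 (0.03 log units; within the scatter). Compound 3 `O=C1/C(=C/c2cccc([N+](=O)[O-])c2)CN(S(=O)(=O)c2ccc(F)cc2)C/C1=C\c1ccccc1F` gives 7040 nM in this assay; the difference between the core of compound 3 and the core of compound 1 is not broken down here, and the two values lie within the scatter of each other.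

Compound 4 `CC(=O)Nc1ccc(S(=O)(=O)N2C/C(=C\c3cccc([N+](=O)[O-])c3)C(=O)/C(=C/c3ccccc3F)C2)cc1` has not been measured. It carries the same change as compound 2, (acetamido in place of fluoro on an aromatic carbon), with an identical description of the place. Because a 1.1-fold lower number from compound 1 to compound 2 (0.03 log units; within the scatter) stayed within the scatter, the step from compound 3 to compound 4 is expected to be about as small, a 1.1-fold lower number from compound 3 to compound 4 (0.04 log units; within the scatter). Compound 4 is therefore estimated at 6400 nM in this assay, with a likely range from 3500 nM to 11500 nM.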

Compound 4, half-maximal inhibitory concentration: 8800 nM
Estimate against measurement, compound 4: 1.4-fold (0.14 log units) below; the range from low to high includes it.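

In this assay, acetamido in place of fluoro gives a 1.3-fold higher number from compound 3 to compound 4 (0.10 log units; within the scatter). Set beside the earlier step, this shows the change carrying over from the core of compound 1 to the core of compound 3 with no difference that can be read between the two steps: the same change on two cores in this assay, a 1.1-fold lower number (0.03 log units; within the scatter) from compound 1 to compound 2 and a 1.3-fold higher number (0.10 log units; within the scatter) from compound 3 to compound 4, 1.3-fold (0.13 log units) apart, within the scatter of two such steps. It does not show that the change is neutral on every core in the series, since it rests on two pairs only, and with both steps within the scatter, no direction can be read from either.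

The compounds shown leave open whether another group at this place, such as an amine, a carboxylic acid or a longer acyl chain, would give a step beyond the scatter. They also leave open whether the result holds on cores with other aromatic substituents.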